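The source may report more compounds than this note shows. Statements on the series, on what has been measured and on what is new or still open speak of the compounds shown alone.

Compound 1 `CCn1c(C(=O)NCC#N)ccc1C(CC)(CC)c1ccc(OCCC(O)(CC)CC)c(C)c1` is the starting point of this comparison. In an assay on cells for agonist activity at vitamin D3 receptor (Homo sapiens), with a stated time of 96 h (on this read-out lower numbers stand for an effect already at smaller amounts and higher numbers for an effect only at larger amounts of compound), compound 1 gives 1080 nM, which places it second highest among the three numbers measured. Its nearest neighbour is compound 3 `CCOC(=O)CN(C)C(=O)c1ccc(C(CC)(CC)c2ccc(OCCC(O)(CC)CC)c(C)c2)n1CC`, which in this assay gives 520 nM; the furthest is compound 2 `CCn1c(C(=O)Nc2cccc(C(F)(F)F)c2)ccc1C(CC)(CC)c1ccc(OCCC(O)(CC)CC)c(C)c1`, which in this assay gives 5900 nM. The measured steps show a 5.5-fold higher number from compound 1 to compound 2 (0.74 log units; beyond the scatter), a 2.1-fold lower number from compound 1 to compound 3 (0.32 log units; beyond the scatter) and an 11-fold lower number from compound 2 to compound 3 (1.05 log units; beyond the scatter).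

Compound 4 `CCC(C)C(NC(=O)c1ccc(C(CC)(CC)c2ccc(OCCC(O)(CC)CC)c(C)c2)n1CC)C(=O)O` has not yet been measured. It differs from compound 1 in one place: 1-carboxy-2-methylbutyl in place of cyanomethyl on an amide-type nitrogen. The two steps that start from compound 1 both alter the group on the same amide-type nitrogen or the carbonyl carbon it belongs to, so both bear on the new change. One of them, a 5.5-fold higher number from compound 1 to compound 2 (0.74 log units; beyond the scatter), raised the number modestly; the other, a 2.1-fold lower number from compound 1 to compound 3 (0.32 log units; beyond the scatter), lowered it modestly. Together they suggest that a change at this position moves the number by a modest amount in either direction, but none of them carries a carboxy group, so the direction for compound 4 is uncertain. Compound 4 is therefore expected to land near compound 1, with the step estimated as a 1.4-fold lower number from compound 1 to compound 4 (0.13 log units; within the scatter). The expected value for compound 4 is 800 nM, with a range from 250 nM to 2600 nM.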

Compound 4, half-maximal effective concentration: 860 nM
Compound 4: middle estimate off by 1.1-fold (0.03 log units), on the low side; the range from low to high includes it.
By their numbers in this assay, from the lowest: compounds 3, 4 and 1 (each within the scatter of the next, the first and the last beyond it); then compound 2.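

In this assay, putting 1-carboxy-2-methylbutyl in place of cyanomethyl on the amide-type nitrogen gives a 1.3-fold lower number from compound 1 to compound 4 (0.10 log units; within the scatter), so a much larger chain carrying a carboxy group and a hydrogen-bond donor leaves the read-out within the scatter of the small nitrile-bearing group. Compound 4 also lies within the scatter of the ester-bearing compound 3, with a 1.7-fold higher number from compound 3 to compound 4 (0.22 log units; within the scatter), although compound 1 and compound 3 are separated by a step beyond the scatter, while the 3-(trifluoromethyl)phenyl group of compound 2 remains apart from the new group, with a 6.9-fold lower number from compound 2 to compound 4 (0.84 log units; beyond the scatter). No measurement at hand gives a reason for these steps.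

Compound 4 brings in the carboxy group and the branched chain together, so the compounds shown cannot separate their contributions; a plain carboxymethyl group or a 2-methylbutyl chain without the carboxylic acid would pull them apart. As far as these compounds go, it also remains open whether the phenyl ring itself or its trifluoromethyl group goes with the high number of compound 2, and how an amine at the end of such a chain would read.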